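Swapping methyl for cyano on the fused ring of compound 3

The compounds below may be only part of what the source reports. "The series", "measured", "known", "first", "only" and "open" are said of these compounds alone.

Compound 3, `CC#C[C@@H](CC(=O)O)c1ccc(OC[C@H]2COc3ccc(C)cc3O2)cc1`, sits second highest of the three numbers measured in a functional assay on HEK293 cells for agonist activity at Free fatty acid receptor 1 (Homo sapiens), read by fluorescence and calcium flux, with a stated time of 10 min (a lower number here means that less compound is needed, a higher number that more compound is needed for the effect), giving 120 nM. Its nearest neighbour is compound 2, `CC#C[C@@H](CC(=O)O)c1ccc(OC[C@H]2COc3ccc(Cl)cc3O2)cc1`, which in this assay gives 50 nM; the furthest is compound 1, `CCOC(CC(=O)O)c1ccc(OCC2COc3ccc(Cl)cc3O2)cc1`, which in this assay gives 640 nM. Going by the values given here, the only single-point change measured so far is the one a 2.4-fold higher number from compound 2 to compound 3 (0.38 log units; beyond the scatter). Compound 4, `CC#C[C@@H](CC(=O)O)c1ccc(OC[C@H]2COc3ccc(C#N)cc3O2)cc1`, has not yet been measured; it differs from compound 3 by cyano in place of methyl on an aromatic carbon. This is a change at the same aromatic carbon that was varied between compound 2 and compound 3, so that step is the only one that bears on it, and it was modest. Among the compounds with values here, no measured pair shows cyano directly. On that basis compound 4 is expected to land close to compound 3, with a step of a 1.5-fold lower number from compound 3 to compound 4 (0.18 log units; within the scatter) that is expected to stay near the scatter. The estimated value for compound 4 in this assay is 80 nM, within a range from 30 nM to 220 nM.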

Compound 4, half-maximal effective concentration: 2100 nM
Beside the measured number, compound 4's estimate is 26-fold (1.42 log units) below it, outside the stated range (above it).
By their numbers in this assay, from the lowest: compound 2; then compound 3; then compound 1; then compound 4.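

At this aromatic carbon the group matters far more in this assay than the earlier swap suggested: beside the modest 2.4-fold higher number from compound 2 to compound 3 (0.38 log units; beyond the scatter) stand an 18-fold higher number from compound 3 to compound 4 (1.24 log units; beyond the scatter) and a 42-fold higher number from compound 2 to compound 4 (1.62 log units; beyond the scatter) as two large rises. Methyl and chloro therefore give numbers much closer to each other than either gives to cyano, which adds one heavy atom to methyl's count and brings a hydrogen-bond acceptor that methyl lacks. No measurement shown here accounts for this jump.

As far as these compounds go, with only methyl, chloro and cyano at this carbon, it remains open whether the large rise is particular to cyano or would also appear with another group, such as methoxy, fluoro or an amine. From the compounds shown here alone, it also remains open whether cyano at this carbon would give a step of similar size on the core of compound 1.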